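The compounds below may be only part of what the source reports. "The series", "measured", "known", "first", "only" and "open" are said of these compounds alone.

Compound 1 `O=C(Nc1nnc(-c2ccc(Cl)cc2)s1)c1ccccc1Cl` and compound 2 `O=C(Nc1nnc(-c2ccc(Cl)cc2)s1)c1ccccc1I` share one core and differ only in the halogen on the benzamide ring. In a functional assay on the whole organism (integument) for inhibition, with Chilo suppressalis as the target, read by scintillation counting, with a stated time of 72 h (a higher number here means a weaker inhibitor, a lower number a stronger inhibitor), compound 1 gives > 5010 nM, which is a limit of the assay rather than a number. In this assay compound 2 gives > 5010 nM, also a limit of the assay. Compound 2 therefore stands at the limit, and so far every value sits there (the limit of > 5010 nM in this assay, at which 2 of the 2 values shown sit). Within the data shown here, the single measured step, a step that the two limits leave unreadable from compound 1 to compound 2, has no readable size because both its ends sit at the limit of > 5010 nM in this assay, at which 2 of the 2 values shown sit.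

Compound 3 `COc1ccccc1C(=O)Nc1nnc(-c2ccc(Cl)cc2)s1` differs from compound 2 by methoxy in place of iodo on an aromatic carbon. Among the measured compounds shown here, no measured step bears on this change, and the one step known gives no size, so no movement beyond the scatter can be expected from it. The step from compound 2 to compound 3 in this assay is expected to be about a step that the limit leaves unreadable from compound 2 to compound 3. Compound 3 is expected to give roughly 8000 nM in this assay, between 2000 nM and 32000 nM, most likely again as a limit.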

Compound 3, half-maximal inhibitory concentration: 53.7 nM
Compound 3: the middle estimate sits 150-fold (2.17 log units) above what was measured; measured number below the stated range.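

Methoxy on this aromatic carbon, ortho to a large group, gives the first readable activity in the series, which the two halogen compounds did not show. In this assay, methoxy in place of iodo gives an at least 93-fold lower number from compound 2 to compound 3 (1.96 log units; beyond the scatter), and methoxy in place of chloro gives an at least 93-fold lower number from compound 1 to compound 3 (1.96 log units; beyond the scatter). Both steps are minimum sizes, and the step between the two halogen compounds remains unreadable: the limit of > 5010 nM in this assay, at which 2 of the 3 values shown sit.

From the compounds shown here alone, whether this activity is particular to methoxy stays open, as hydroxy, ethoxy or an amine on the same carbon would be needed to tell. Also open, going by these compounds, is whether methoxy on another carbon of this ring, or a second methoxy, would hold the value of compound 3, 53.7 nM.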